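Removing the Methoxy Group from Compound 3

The source may hold more compounds than are shown below. What is called first, only, known or untested is meant among the compounds shown, and "the series" means these compounds.

Measured compounds and their values in an assay on isolated protein for inhibition of patatin-like phospholipase domain-containing protein 2 (Mus musculus), tested at 200 uM; a lower number here means less inhibition, a higher number more inhibition at the concentration tested (going by the name of the read-out):
Compound 1 `CCOC(=O)c1nn(-c2ccc(OCC)cc2)cc1O` gives 67%.
Compound 2 `CCOc1ccc(-n2cc(O)c(C(=O)OC)n2)cc1` gives 64%.
Compound 3 `CCOC(=O)c1nn(-c2ccc(OCC)cc2)cc1OC` gives 63%.

Compound 3 has the lowest of the three numbers in this assay, but its two neighbours sit close: compound 2 is nearest, and compound 1 furthest, and both gaps are within the scatter, so the three compounds cannot be put in order on these data. The two measured steps are likewise small. The step of a number 3 percentage points lower from compound 1 to compound 2 (within the scatter) is within the scatter, and the step of a number 4 percentage points lower from compound 1 to compound 3 (within the scatter) is within the scatter as well.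

Compound 4 `CCOC(=O)c1ccn(-c2ccc(OCC)cc2)n1` is the next compound to be tested. Relative to compound 3 the change is hydrogen in place of methoxy on an aromatic carbon. Going by the values given here, the step that bears most on it is the one from compound 1 to compound 3, where the oxygen on the aromatic ring went from bearing hydrogen to bearing methyl with no change beyond the scatter; compound 4 now loses that oxygen altogether. Among the compounds with values here, on the only related step, this change looks small, so no step beyond the scatter is expected here. The expected result for compound 4 is 63%, with a range from 48% to 76%, an estimated step of no change at the digits printed from compound 3 to compound 4 (within the scatter).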

Compound 4, a percentage reported as inhibition, at one concentration (the size of the read-out at that concentration, not a potency): 89%
Compound 4: middle estimate off by 26 percentage points, on the low side, and the stated range ends below it.
By their numbers in this assay, from the lowest: compounds 3, 2 and 1 (each within the scatter of the next); then compound 4.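

In this assay, going by these compounds alone, the earlier compounds could not tell hydroxy from methoxy on this aromatic carbon, but removing the oxygen altogether gives a clear separation: replacing methoxy with hydrogen yields a number 26 percentage points higher from compound 3 to compound 4 (beyond the scatter) and replacing hydroxy with hydrogen yields a number 22 percentage points higher from compound 1 to compound 4 (beyond the scatter) in the same direction. Among the three substituents seen on this carbon, the one next to the ring atom that bears an ethoxycarbonyl group, hydrogen therefore stands apart, while hydroxy and methoxy remain indistinguishable, so whether that oxygen bears hydrogen or methyl matters less here than whether it is present. Nothing shown here explains why the compound with hydrogen on this carbon gives the higher number.

On these data alone, it remains open whether a small replacement on this carbon, such as a fluorine atom, a methyl group or an amine, would group with hydrogen or with the two oxygen substituents. It is also unknown whether the higher number would persist with a carboxylic acid in place of the ethyl ester or a longer chain in place of the ethoxy group, and these single-concentration percentages do not establish potency.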